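The source may hold more compounds than are shown below. What is called first, only, known or untested is meant among the compounds shown, and "the series" means these compounds.

Measured so far, all in a functional assay on PC-12 cells (Rattus norvegicus) for cytotoxicity, read by MTT assay, with stated times of 2 h and 24 h, tested at 10 uM; a lower number here means a weaker effect, a higher number a stronger effect of the compound at the concentration tested:
compound 1, `Cc1ccc(-n2nc(-c3ccc(C(F)(F)F)cc3O)nc2-c2ccccc2O)cc1`: 102%
compound 2, `CC(C)c1ccc(-n2nc(-c3ccc(C(F)(F)F)cc3O)nc2-c2ccccc2O)cc1`: 108%
compound 3, `Oc1cc(C(F)(F)F)ccc1-c1nc(-c2ccccc2O)n(-c2ccc(Br)cc2)n1`: 100%

The three compounds share one core and differ only in the group carried on an aromatic nitrogen of the five-membered ring. Compound 3 carries a 4-bromophenyl there and has the lowest of the three numbers, yet the gaps to the others are small: the step of a number 2 percentage points lower from compound 1 to compound 3 (within the scatter) and the step of a number 8 percentage points lower from compound 2 to compound 3 (within the scatter) both fall within the scatter, so the three compounds cannot be told apart on these numbers.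

Compound 4, `Cc1ccc(-n2nc(-c3ccc(C(F)(F)F)cc3O)nc2-c2ccccc2O)c(C)c1`, is the next compound in this series. Its change from compound 3 is 2,4-dimethylphenyl in place of 4-bromophenyl on an aromatic nitrogen.

Within the data shown here, every measured step so far is an exchange of the group on that same aromatic nitrogen: methyl to isopropyl in a number 6 percentage points higher from compound 1 to compound 2 (within the scatter), methyl to bromo in a number 2 percentage points lower from compound 1 to compound 3 (within the scatter), isopropyl to bromo in a number 8 percentage points lower from compound 2 to compound 3 (within the scatter). None moved the number beyond the scatter. For a further exchange on the same nitrogen, no step beyond the scatter in this assay is therefore expected, in either direction. The step of a number 3 percentage points higher from compound 3 to compound 4 (within the scatter) is the estimated consequence. Compound 4 is expected to give 103%, between 90% and 116%.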

Compound 4, a percentage reported as activity, at one concentration (the size of the read-out at that concentration, not a potency): 106%
Beside the measured number, compound 4's estimate is 3 percentage points below it; the measured number falls inside the stated range.
By their numbers in this assay, from the lowest: compounds 3, 1, 4 and 2 (each within the scatter of the next).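

In this assay, among these compounds, the earlier compounds differ by a single group on the aromatic ring carried by the nitrogen, whereas compound 4 has two methyl groups on that ring, and adding the second gives a number 4 percentage points higher from compound 1 to compound 4 (within the scatter). The exchanges that link it to the other compounds give a number 6 percentage points higher from compound 3 to compound 4 (within the scatter) and a number 2 percentage points lower from compound 2 to compound 4 (within the scatter), so neither this extra methyl nor the replacement of 4-bromophenyl or 4-isopropylphenyl by 2,4-dimethylphenyl separates compound 4 from the earlier three on these numbers. Nothing available explains why these numbers lie so close together.

The groups shown on that ring are limited to methyl, isopropyl and bromo, so it remains open whether an amine or a carboxylic acid there would give a step beyond the scatter. The trifluoromethyl group and the two hydroxyl groups of the shared core are the same in all four compounds, leaving open what would follow if, for example, a methoxy group took the place of a hydroxyl group.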